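Aryl hydrazone variation on a shared diaryl ether core

This account rests on a few compounds, and the source may have more. Where it says the series, first, only, none or still open, it means among the compounds named here.

Values in a functional assay on U-87MG ATCC cells (Homo sapiens) for cytotoxicity, read by MTT assay, with a stated time of 72 h; on this read-out lower numbers stand for stronger inhibition and higher numbers for weaker inhibition:
compound 1, `CN(C)CCn1cnnc1-c1cc(Oc2ccc(NC(=O)N/N=C/c3cccc(Br)c3)cc2F)ccn1`: 830 nM
compound 2, `CN(C)CCn1cnnc1-c1cc(Oc2ccc(NC(=O)N/N=C/c3cccc(O)c3)cc2F)ccn1`: > 100000 nM, a limit of the assay and not a number
compound 3, `CN(C)CCn1cnnc1-c1cc(Oc2ccc(NC(=O)N/N=C/c3ccc(F)cc3)cc2F)ccn1`: 2310 nM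

Compound 1 gives the lowest of the two numbers; the nearest is compound 3, with a 2.8-fold higher number from compound 1 to compound 3 (0.44 log units; beyond the scatter). Compound 2 sits at the limit of > 100000 nM in this assay, at which 1 of the 3 values shown sits, so its place relative to the other two is known only as an at least 120-fold higher number from compound 1 to compound 2 (2.08 log units; beyond the scatter) and an at least 43-fold lower number from compound 2 to compound 3 (1.63 log units; beyond the scatter).

Compound 4, `CN(C)CCn1cnnc1-c1cc(Oc2ccc(NC(=O)N/N=C/c3c(Cl)cccc3Cl)cc2F)ccn1`, differs from compound 1 by 2,6-dichlorophenyl in place of 3-bromophenyl on a carbon with a double bond to nitrogen. The two measured steps that bear on this change are the exchange of one halogen-bearing aryl for another, a 2.8-fold higher number from compound 1 to compound 3 (0.44 log units; beyond the scatter), which was modest, and the exchange of bromo for hydroxy, an at least 120-fold higher number from compound 1 to compound 2 (2.08 log units; beyond the scatter), which was large. Compound 4 keeps a halogen-bearing aryl and introduces no donor or acceptor, so the second pattern is not expected to apply; the first suggests a modest shift, if any, in this assay.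

Compound 4 is therefore expected to give 1500 nM, with a range of 400 nM to 6000 nM, an expected 1.8-fold higher number from compound 1 to compound 4 (0.26 log units; within the scatter) that may not exceed the scatter.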

Compound 4, half-maximal inhibitory concentration: > 100000 nM
Compound 4: a limit, no number; the forecaster's own chance of this, stated with the estimate: 10%; at least 66-fold (1.82 log units) between middle value and limit.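

In this assay compound 4 gives > 100000 nM, a limit of the assay and not a number. The change of aryl on the carbon with a double bond to nitrogen gives an at least 120-fold higher number from compound 1 to compound 4 (2.08 log units; beyond the scatter) and an at least 43-fold higher number from compound 3 to compound 4 (1.63 log units; beyond the scatter); 3-bromophenyl and 2,6-dichlorophenyl both count 0 hydrogen-bond donors and 0 hydrogen-bond acceptors, so a loss of this size at this position is not confined to the hydroxy exchange seen with compound 2. A halogen on the aryl does not by itself keep a measurable value, since compound 1 and compound 3 give numbers while compound 4 goes against that pattern, and compound 2 and compound 4 now share one ceiling: the limit of > 100000 nM in this assay, at which 2 of the 4 values shown sit.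

Compound 2 and compound 4 are both limits, so the step between them cannot be read. From the compounds shown here alone, whether an unsubstituted phenyl, a single chloro group or a methoxy group on this aryl would give a number stays open, as does how far either limited compound lies past the ceiling.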